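Ester to carbamate on the side chain of compound 3

The compounds below may be only part of what the source reports. "The series", "measured", "known", "first", "only" and "open" are said of these compounds alone.

Measured so far:
compound 1 `COCc1c(C)nc2c(OCc3ccccc3)cccn12` 99%
compound 2 `Cc1nc2c(OCc3ccccc3)cccn2c1Cl` 93%
compound 3 `COC(=O)Cc1c(C)nc2c(OCc3ccccc3)cccn12` 23%

In a functional assay on the whole organism with Rattus norvegicus as the target, with a stated time of 4 h, at a dose of 40 mg/kg by the intraperitoneal route (on this read-out lower numbers stand for less inhibition and higher numbers for more inhibition at the one dose given (going by the name of the read-out)), compound 3 stands lowest of the three; its nearest neighbour is compound 2, and compound 1 lies further off, both beyond the scatter. Compound 4 `Cc1nc2c(OCc3ccccc3)cccn2c1COC(=O)N(C)C` has not yet been measured. It differs from compound 3 in one place: (dimethylcarbamoyl)oxy in place of methoxycarbonyl on a saturated chain carbon bound to an aromatic carbon.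

Within the data shown here, two measured steps bear on this position. a number 76 percentage points lower from compound 1 to compound 3 (beyond the scatter) shows that putting methoxycarbonyl on the saturated chain carbon in place of methoxy removed most of the effect, and a number 70 percentage points lower from compound 2 to compound 3 (beyond the scatter) shows the same for (methoxycarbonyl)methyl entering in place of chloro. Compound 4 no longer carries methoxycarbonyl on that carbon; instead, as in compound 1, an oxygen-linked group sits there, though a larger one by the counted atoms. Among the measured compounds shown here, no measured pair tests (dimethylcarbamoyl)oxy itself, so the direction rests only on the removal of methoxycarbonyl. Going by these compounds, a rise back toward compound 1 is expected, but a wide range is estimated since the entering group is untested.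

For compound 4 a value of 70% is estimated, between 35% and 97%, which means an expected step of a number 47 percentage points higher from compound 3 to compound 4 (beyond the scatter).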

Compound 4, a percentage reported as inhibition, in the whole organism at one dose (the size of the read-out at that dose, not a potency): 75%
Estimate against measurement, compound 4: 5 percentage points below, within the range that was stated.
By their numbers in this assay, from the lowest: compound 3; then compound 4; then compounds 2 and 1 (each within the scatter of the next).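

In this assay, the step of a number 52 percentage points higher from compound 3 to compound 4 (beyond the scatter) shows that the low number of compound 3 does not extend to every group carrying a carbonyl on this saturated chain carbon: the change to (dimethylcarbamoyl)oxy restores much of the effect, although methoxycarbonyl and (dimethylcarbamoyl)oxy have the same counts of hydrogen-bond donors and acceptors. The recovery is only partial, as the carbamate stands under the methoxymethyl of compound 1, with dimethylcarbamoyl in place of methyl on the oxygen giving a number 24 percentage points lower from compound 1 to compound 4 (beyond the scatter), and under the chloro of compound 2, with ((dimethylcarbamoyl)oxy)methyl in place of chloro giving a number 18 percentage points lower from compound 2 to compound 4 (beyond the scatter). No measurement at hand bears on what lies behind these differences.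

The compounds shown leave open whether the oxygen on the saturated carbon or the dimethylcarbamoyl part accounts for the recovery, which a hydroxymethyl group or an unsubstituted carbamate at this place could help to separate. They also leave open how a dimethylaminomethyl group, a carboxylic acid or a longer ether chain would read here at the one dose given.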